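Trading fluoro for nitro on the aryl end of compound 1

The compounds below may be only part of what the source reports. "The series", "measured", "known", "first", "only" and "open" are said of these compounds alone.

Compound 1, `CC1=C(/C=C/C(=O)/C=C/c2cccc(F)c2)C(C)(C)CCC1O`, gives 16000 nM in a functional assay on PC-3 cells (Homo sapiens) for cytotoxicity, read by MTT assay, with a stated time of 72 h; on this read-out lower numbers stand for stronger inhibition and higher numbers for weaker inhibition.
Compound 2, `CC1=C(/C=C/C(=O)/C=C/c2ccc(F)cc2)C(C)(C)CCC1O`, gives 6200 nM in this assay.

For the measured compounds named here, compound 1 stands highest of the two numbers in this assay; the only step to it, a 2.6-fold lower number from compound 1 to compound 2 (0.41 log units; beyond the scatter), changes only where the fluoro sits on the ring. Compound 3, `CC1=C(/C=C/C(=O)/C=C/c2cccc([N+](=O)[O-])c2)C(C)(C)CCC1O`, differs from compound 1 by nitro in place of fluoro on an aromatic carbon. Going by the values given here, no measured step swaps one group for another, so that fluoro step offers a rough scale only, with no clear direction. Compound 3 is therefore expected to give 12000 nM, within 4000 nM to 40000 nM. That expectation amounts to a 1.3-fold lower number from compound 1 to compound 3 (0.12 log units; within the scatter).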

Compound 3, half-maximal inhibitory concentration: 5800 nM
Beside the measured number, compound 3's estimate is 2.1-fold (0.32 log units) above it; measured number inside the range.
By their numbers in this assay, from the lowest: compounds 3 and 2 (each within the scatter of the next); then compound 1.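

Keeping the position fixed and changing the group on this aromatic carbon gives a 2.8-fold lower number from compound 1 to compound 3 (0.44 log units; beyond the scatter) in this assay, so the number responds to the identity of the group as well as to where the fluoro sits. The earlier pair showed only the effect of moving the fluoro, whereas this step shows that nitro in place of fluoro also counts here. Nothing available explains why this exchange lowers the number.

As far as these compounds go, whether an amine or a methoxy group on this carbon would lower the number as well remains open. So does what nitro would give at the place where compound 2 carries its fluoro.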